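One Methyl Added to Compound 1

The source may report more compounds than this note shows. Statements on the series, on what has been measured and on what is new or still open speak of the compounds shown alone.

Among the measured compounds shown here, compound 1 `C=CC(=O)Nc1nc(-c2ccccc2)cs1` gives 18600 nM in a functional assay on HCT-116 cells (Homo sapiens) for antiproliferative activity, read by MTT assay, with a stated time of 72 h (a lower number here means a stronger inhibitor, a higher number a weaker inhibitor), the only true number available so far in this small set. Compound 2 `C=CC(=O)Nc1nc(-c2ccccc2O)cs1` differs from it by hydroxy in place of hydrogen on an aromatic carbon. For compound 2 the result is a limit and not a number: > 30000 nM.

The next structure, compound 3 `C=CC(=O)Nc1nc(-c2ccccc2)c(C)s1`, carries a different change from the core of compound 1: methyl in place of hydrogen on an aromatic carbon. In words, this is methyl in place of hydrogen on an aromatic carbon.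

For the measured compounds named here, only one measured step can serve as a guide, and it involves a different group in a different place. That step is an at least 1.6-fold higher number from compound 1 to compound 2 (0.20 log units; that floor lies within the scatter), so compound 2 offers no firm sign of either size or direction for the methyl change. With so little evidence, the expected result is no shift beyond the scatter, and the estimated step is a 1.0-fold lower number from compound 1 to compound 3 (0.01 log units; within the scatter). Compound 3 is expected to give about 18000 nM, with an estimated range from 8000 nM to 30000 nM.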

Compound 3, half-maximal inhibitory concentration: 20100 nM
Compound 3: middle estimate off by 1.1-fold (0.05 log units), on the low side; measured number inside the range.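

In this assay, placing methyl on the aromatic carbon next to the ring sulfur gives a 1.1-fold higher number from compound 1 to compound 3 (0.03 log units; within the scatter). Among the compounds shown here, this is the first change to the core of compound 1 that can be read with a true number on each side, and it shows that this position can carry a methyl while compound 1 and compound 3 remain impossible to tell apart in this read-out. Compound 2 stays a limit and not a number, so only one step in this small set has a true number at both ends: the limit of > 30000 nM in this assay, at which 1 of the 3 values shown sits.

On these data alone, a single methyl says little about the position as a whole, so it remains open whether a longer chain such as ethyl, an amine or a carboxylic acid on the same carbon would also leave the result within the scatter. The compounds shown also leave open whether methyl would give a similar result elsewhere on the shared core, since this one position is the only place where its effect can be read.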